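From 4-(tert-butyl)phenyl to 3-hydroxyphenyl at a limit

The compounds below may be only part of what the source reports. "The series", "measured", "known", "first", "only" and "open" are said of these compounds alone.

In a functional assay on A549 cells (Homo sapiens) for antiproliferative activity, read by MTT assay, with a stated time of 48 h (a lower number here means a stronger inhibitor, a higher number a weaker inhibitor), compound 1 (`C/C(=C\CC/C(C)=C/CC[C@@H]1[C@@]2(C)CCC(=O)C(C)(C)[C@H]2CC[C@@]1(C)O)CC/C=C(\C)C(=O)OCc1cn(-c2ccccc2)nn1`) gives > 150000 nM as a limit and not a number. Compound 2 (`C/C(=C\CC/C(C)=C/CC[C@@H]1[C@@]2(C)CCC(=O)C(C)(C)[C@H]2CC[C@@]1(C)O)CC/C=C(\C)C(=O)OCc1cn(-c2ccc(C(C)(C)C)cc2)nn1`) gives > 150000 nM, also a limit, so it stands only at the limit of > 150000 nM in this assay, at which 2 of the 2 values shown sit, with no number of its own. Among the compounds with values here, the only measured change is a step that the two limits leave unreadable from compound 1 to compound 2 and so offers no size to carry forward. Compound 3 (`C/C(=C\CC/C(C)=C/CC[C@@H]1[C@@]2(C)CCC(=O)C(C)(C)[C@H]2CC[C@@]1(C)O)CC/C=C(\C)C(=O)OCc1cn(-c2cccc(O)c2)nn1`) has 3-hydroxyphenyl in place of 4-(tert-butyl)phenyl on an aromatic nitrogen. With no readable step as a guide, the expected change in this assay is none beyond the scatter, estimated as a number no higher from compound 2 to compound 3 (the limit leaves the size open) here. For compound 3 the expected value is 150000 nM with an estimated range of 70000 nM to 300000 nM around it.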

Compound 3, half-maximal inhibitory concentration: 42800 nM
For compound 3 the middle estimate is 3.5-fold (0.54 log units) above the measured one; the whole stated range lies above it.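

Hydroxy on the aromatic ring is the first change here to give a readable result in this assay, whereas the step that adds tert-butyl cannot be read. Hydroxy in place of hydrogen gives an at least 3.5-fold lower number from compound 1 to compound 3 (0.54 log units; beyond the scatter), and replacing 4-(tert-butyl)phenyl with 3-hydroxyphenyl gives an at least 3.5-fold lower number from compound 2 to compound 3 (0.54 log units; beyond the scatter). Only compound 3 has a number of its own, and the other two compounds stay at a limit: the limit of > 150000 nM in this assay, at which 2 of the 3 values shown sit.

Going by these compounds, whether an amine or a carboxylic acid in place of the hydroxy would also give a number stays open. So does whether a second hydroxy would lower the number further.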